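A Second Methyl Added to a Compound at the Limit

The source may hold more compounds than are shown below. What is called first, only, known or untested is meant among the compounds shown, and "the series" means these compounds.

Compound 1 `O=C(COc1ccc2c(=O)ccoc2c1)Nc1cccc(NC(=O)c2ccccc2)c1` and compound 2 `Cc1ccc(C(=O)Nc2cccc(NC(=O)COc3ccc4c(=O)ccoc4c3)c2)cc1` share one core and differ by methyl in place of hydrogen on an aromatic carbon. In an assay on isolated protein for inhibition of Rho-associated protein kinase 2 (Homo sapiens), read by scintillation counting, radiometric assay and 33P incorporation, with a stated time of 40 min, in the presence of a further agent that is not named here (on this read-out higher numbers stand for weaker inhibition and lower numbers for stronger inhibition), compound 1 gives 16 nM. In this assay compound 2 gives 22 nM. The step is a 1.4-fold higher number from compound 1 to compound 2 (0.14 log units; within the scatter), so the added methyl changes little here.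

Compound 3 `Cc1cc(NC(=O)COc2ccc3c(=O)ccoc3c2)cc(NC(=O)c2ccc(N(C)C)cc2)c1` is built on a different core, and the difference between the two cores is not broken down here. In this assay compound 3 gives only > 10000 nM, which is a limit of the assay and not a number.

Compound 4 `Cc1cc(NC(=O)COc2ccc3c(=O)ccoc3c2)cc(NC(=O)c2ccc(N(C)C)cc2)c1C` differs from compound 3 by methyl in place of hydrogen on an aromatic carbon. This is the same kind of change as that from compound 1 to compound 2, but the surroundings differ: in compound 4 the new methyl sits ortho to a ((4-(dimethylamino)phenyl)carbonyl)amino group and ortho to a methyl group, as well as para to a large group, whereas in compound 2 it sits only para to a large group. Because compound 3 sits at the limit (the limit of > 10000 nM in this assay, at which 1 of the 3 values shown sits), and because the earlier methyl made only a 1.4-fold higher number from compound 1 to compound 2 (0.14 log units; within the scatter), the step from compound 3 to compound 4 is expected to be a step that the limit leaves unreadable from compound 3 to compound 4. Compound 4 is estimated to give 15000 nM, likely between 3000 nM and 60000 nM, most probably again only as a limit.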

Compound 4, half-maximal inhibitory concentration: 374 nM
Compound 4: the middle estimate sits 40-fold (1.60 log units) above what was measured; measured number outside the range, below it.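

Placed on the core of compound 3, the added methyl gives an at least 26-fold lower number from compound 3 to compound 4 (1.42 log units; beyond the scatter) in this assay. Set beside the same change on the core of compound 1, the result does not carry over from one core to the other: the same change on two cores in this assay, a 1.4-fold higher number (0.14 log units; within the scatter) from compound 1 to compound 2 and an at least 26-fold lower number (1.42 log units; beyond the scatter) from compound 3 to compound 4, at least 36-fold (1.56 log units) apart, beyond the scatter of two such steps

This shows that in this series the effect of a methyl on one core cannot simply be assumed for another, but it rests on only one pair per core, gives no reason for the gap, and fixes the larger step only as a bound: the limit of > 10000 nM in this assay, at which 1 of the 4 values shown sits.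

The compounds shown leave open whether an ethyl group or a chlorine atom in the place of the new methyl in compound 4 would give a similar number. They also leave open how much the dimethylamino group and the methyl already present in compound 3 each contribute to the difference between the two cores.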